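From ethyl to methyl on the shared core

This account rests on a few compounds, and the source may have more. Where it says the series, first, only, none or still open, it means among the compounds named here.

In an ADME assay for permeability, using PAMPA, at pH 4 (on this read-out lower numbers stand for lower permeability and higher numbers for higher permeability), compound 1 (`CCc1c(C)[nH]c2cc(OC)c(Cl)cc2c1=O`) gives 96.4 10^-6 cm/s and compound 2 (`CCc1c(C)[nH]c2cc(OC)c(Br)cc2c1=O`) gives 81.9 10^-6 cm/s as its number. For the measured compounds named here, these two values lie within the scatter of each other, so compound 1 stands level with the only other measured compound. The step of a 1.2-fold lower number from compound 1 to compound 2 (0.07 log units; within the scatter) comes with bromo in place of chloro on an aromatic carbon. Compound 3 (`COc1cc2[nH]c(C)c(C)c(=O)c2cc1Cl`) has not yet been measured. It differs from compound 1 by hydrogen in place of methyl on a saturated chain carbon bound to an aromatic carbon in one change, hydrogen in place of methyl on a saturated chain carbon bound to an aromatic carbon, which reads ethyl to methyl. Going by the values given here, no measured step covers this change. Among the compounds with values here, with a 1.2-fold lower number from compound 1 to compound 2 (0.07 log units; within the scatter) as the only indirect guide, no step beyond the scatter is expected in this assay for it. a 1.2-fold lower number from compound 1 to compound 3 (0.08 log units; within the scatter) is the estimated step. Compound 3 is estimated at 80 10^-6 cm/s on this read-out, with 40 10^-6 cm/s to 150 10^-6 cm/s as the expected range.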

Compound 3, apparent permeability: 37 10^-6 cm/s
Compound 3: the middle estimate sits 2.2-fold (0.33 log units) above what was measured; the measured number lies below the stated range.
By their numbers in this assay, from the lowest: compound 3; then compounds 2 and 1 (each within the scatter of the next).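

Within this assay, ethyl to methyl at this saturated chain carbon bound to an aromatic carbon brings a 2.6-fold lower number from compound 1 to compound 3 (0.42 log units; beyond the scatter) and so moves the number more than the scatter allows. The only earlier step, bromo in place of chloro on an aromatic carbon, gave a 1.2-fold lower number from compound 1 to compound 2 (0.07 log units; within the scatter) and showed no such movement, so this chain is the one place among the compounds shown where a single change separates two numbers. Nothing available here accounts for the size of this step.

The compounds shown leave open whether a longer chain such as propyl at this place would give a number closer to that of compound 1 or further from it. They also leave open whether ethyl to methyl gives a step of similar size when bromo stands in place of chloro.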